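A few compounds are considered here, and "the series" means these few. Any claim that something is new, unique, unknown or untested is made for them only; others in the source may bear on it.

Measured so far in a physicochemical assay for solubility, in the presence of a further agent that is not named here; on this read-out higher numbers stand for higher solubility and lower numbers for lower solubility:
compound 1, `CN(C)CCNc1n[n+]([O-])c2ccc(C(C)(C)C)cc2[n+]1[O-]`: 38000000 nM
compound 2, `CC(C)(C)c1ccc2c(c1)[n+]([O-])c(NCCN1CCCCC1)n[n+]2[O-]`: 28000000 nM
compound 3, `CCOc1ccc2c(c1)[n+]([O-])c(NCCN(C)C)n[n+]2[O-]`: a limit of this assay, > 50000000 nM

The three compounds share one core and differ at two places. Compound 2 differs from compound 1 by piperidin-1-yl in place of dimethylamino on a saturated chain carbon, two bonds along the chain from a nitrogen on an aromatic ring, and that step reads a 1.4-fold lower number from compound 1 to compound 2 (0.13 log units; within the scatter). Compound 3 differs from compound 1 by ethoxy in place of tert-butyl on an aromatic carbon, a step of an at least 1.3-fold higher number from compound 1 to compound 3 (0.11 log units; that floor lies within the scatter). The value of compound 3 is only a limit of this assay; (the limit of > 50000000 nM in this assay, at which 1 of the 3 values shown sits).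

Compound 4, `CCOc1ccc2c(c1)[n+]([O-])c(NCCN1CCCCC1)n[n+]2[O-]`, has not yet been measured in this assay. It differs from compound 3 by piperidin-1-yl in place of dimethylamino on a saturated chain carbon, two bonds along the chain from a nitrogen on an aromatic ring, which is the same change as the one from compound 1 to compound 2, at the same place on the chain; the cores of compound 3 and compound 4 differ from those of compound 1 and compound 2 in the way described above.

Because that change made a 1.4-fold lower number from compound 1 to compound 2 (0.13 log units; within the scatter), the step from compound 3 to compound 4 is expected to be of similar size, a number no higher from compound 3 to compound 4 (the limit leaves the size open). Compound 4 is therefore estimated at 50000000 nM, expected to lie between 25000000 nM and 100000000 nM, and the result may again come out only as a limit of this assay.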

Compound 4, solubility: > 49000000 nM
Compound 4 ended at the assay's limit (the forecaster's own chance of this, stated with the estimate: 60%); the middle value lies beyond the limit too.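

In this assay compound 4 gives > 49000000 nM, which is a limit of the assay and not a number. Compound 3 also stands at a limit of this assay, so the step made by piperidin-1-yl in place of dimethylamino on this core cannot be read: compound 4 stays at a limit, as compound 3 does, but this neither confirms nor rules out that the change has the same size on both cores. Within the data shown here, the one step that can be read, an at least 1.7-fold higher number from compound 2 to compound 4 (0.24 log units; that floor lies within the scatter), belongs to ethoxy in place of tert-butyl on an aromatic carbon, so it says nothing direct about the change on the chain.

The compounds shown leave open where compound 3 and compound 4 really stand beyond their limits, and so how the two cores compare for this change. They also leave open how this assay would read with a morpholin-4-yl group at the end of the chain, or with a longer chain.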